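Varying the amino substituent on the benzamide arm

A few compounds are considered here, and "the series" means these few. Any claim that something is new, unique, unknown or untested is made for them only; others in the source may bear on it.

Measured compounds:
- compound 1 `CCN(Cc1ccc(Br)cc1)c1cccc(C(=O)N2CCc3ccc(OS(N)(=O)=O)cc3C2)c1`: 24.2%
- compound 2 `CCN(Cc1cccnc1)c1cccc(C(=O)N2CCc3ccc(OS(N)(=O)=O)cc3C2)c1`: 14.3%
- compound 3 `CCCN(CCC)c1cccc(C(=O)N2CCc3ccc(OS(N)(=O)=O)cc3C2)c1`: 8.3%

In an assay on HEK293 cells for inhibition of Steryl-sulfatase (Homo sapiens), tested at 0.1 uM (a higher number here means a stronger effect of the compound at the concentration tested, a lower number a weaker effect), compound 3 gives 8.3%, the lowest of the three numbers. Compound 2 sits nearest to it, and that gap is within the scatter a number 6 percentage points lower from compound 2 to compound 3 (within the scatter). Compound 1 is furthest, and the step of a number 15.9 percentage points lower from compound 1 to compound 3 (beyond the scatter) lies beyond the scatter, though only modestly so.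

Compound 4 `CN(CCN1CCCCC1)c1cccc(C(=O)N2CCc3ccc(OS(N)(=O)=O)cc3C2)c1` has not been measured. It differs from compound 3 at the same aromatic carbon that was varied in the two steps above: methyl(2-(piperidin-1-yl)ethyl)amino in place of dipropylamino on an aromatic carbon. Both measured steps that bear on this position ran from a larger amino group to dipropylamino and went downward, one beyond the scatter and one within it. Going the other way, from dipropylamino to a larger group, a small upward move is therefore expected in this assay, but nothing that clearly exceeds the scatter. For compound 4 the expected step is a number 4.7 percentage points higher from compound 3 to compound 4 (within the scatter). Compound 4 is thus estimated at 13%, with a range from 3% to 26%.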

Compound 4, a percentage reported as inhibition, at one concentration (the size of the read-out at that concentration, not a potency): 24.5%
Compound 4: the middle estimate sits 11.5 percentage points below what was measured; low and high end bracket the measured number.
By their numbers in this assay, from the lowest: compounds 3, 2, 1 and 4 (each within the scatter of the next, the first and the last beyond it).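

At this aromatic carbon, methyl(2-(piperidin-1-yl)ethyl)amino in place of dipropylamino gives a number 16.2 percentage points higher from compound 3 to compound 4 (beyond the scatter) in this assay. Among these compounds, the same group in place of ethyl((pyridin-3-yl)methyl)amino gives a number 10.2 percentage points higher from compound 2 to compound 4 (beyond the scatter) and is the first change in the set to move the read-out upward beyond the scatter from compound 2. Against the (4-bromobenzyl)(ethyl)amino group the result is a number 0.3 percentage points higher from compound 1 to compound 4 (within the scatter), so a group whose only ring is a six-membered non-aromatic one matches the aryl-bearing group of compound 1 in this assay. Nothing available here accounts for these differences.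

From the compounds shown here alone, it remains open whether the piperidine ring itself matters, since a morpholine or an open diethylamino end on the same chain would test that. Going by these compounds, the effect of a longer chain leading to the ring, or of ethyl in place of methyl on the nitrogen, also remains unknown.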